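Sulfur-to-selenium exchange across two cores: working notes

A few compounds are considered here, and "the series" means these few. Any claim that something is new, unique, unknown or untested is made for them only; others in the source may bear on it.

Measured so far in a functional assay on PC-3 cells (Homo sapiens) for cytotoxicity, read by MTT assay, with a stated time of 72 h; a higher number here means that more compound is tolerated, a lower number that less compound is tolerated:
compound 1, `CS/C(=N\C(=O)c1sccc1Cl)NC(=O)c1sccc1Cl`: 90100 nM
compound 2, `CS/C(=N\C(=O)c1cc(-c2ccccc2)nc2ccccc12)NC(=O)c1cc(-c2ccccc2)nc2ccccc12`: a limit of the assay, > 100000 nM
compound 3, `C[Se]/C(=N\C(=O)c1cc(-c2ccccc2)nc2ccccc12)NC(=O)c1cc(-c2ccccc2)nc2ccccc12`: a limit of the assay, > 100000 nM

In this assay, going by the values given here, compound 1 gives 90100 nM, the only number among the three values. Compound 2 reaches only a limit of the assay, > 100000 nM. Compound 3 likewise reaches only a limit, > 100000 nM. The difference between the core of compound 1 and the core of compound 2 is not broken down here.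

From compound 2 to compound 3 the change is a group of 2 heavy atoms (1 carbon, 1 selenium; no ring) in place of a group of 2 heavy atoms (1 carbon, 1 sulfur; no ring), on a carbon with a double bond to nitrogen. The step that the two limits leave unreadable from compound 2 to compound 3 cannot be sized, because both values sit at the limit of > 100000 nM in this assay, at which 2 of the 3 values shown sit. So the one measured instance of this exchange tells nothing about its effect on tolerated concentration.

Compound 4, `C[Se]/C(=N\C(=O)c1sccc1Cl)NC(=O)c1sccc1Cl`, has not yet been measured in this assay. It differs from compound 1 by a group of 2 heavy atoms (1 carbon, 1 selenium; no ring) in place of a group of 2 heavy atoms (1 carbon, 1 sulfur; no ring), on a carbon with a double bond to nitrogen, the same change at the same place as that from compound 2 to compound 3. In this assay a step of a 1.3-fold lower number from compound 1 to compound 4 (0.11 log units; within the scatter) is expected from compound 1 to compound 4, set beside a step that the two limits leave unreadable from compound 2 to compound 3. This rests on compound 1 giving 90100 nM and on the measured step being unreadable, so only a small shift is assumed. Compound 4 is therefore estimated at 70000 nM, expected to fall between 25000 nM and 150000 nM.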

Compound 4, concentration lethal to 50% of the cells: > 100000 nM
Compound 4: a limit, no number; the forecaster's own chance of this, stated with the estimate: 35%; at least 1.4-fold (0.15 log units) between middle value and limit.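

In this assay compound 4 gives > 100000 nM, which is a limit of the assay and not a number. The exchange of methylsulfanyl for its selenium counterpart, on a carbon with a double bond to nitrogen, therefore reads on the core of compound 1 as an at least 1.1-fold higher number from compound 1 to compound 4 (0.04 log units; that floor lies within the scatter): this is a floor and not a size, so it shows no measured shift in either direction beyond the scatter and does not fix how large the true step is. The same exchange on the core of compound 2 cannot be read at all, and whether the change carries from one core to the other cannot be judged, because neither step has a size: the limit of > 100000 nM in this assay, at which 3 of the 4 values shown sit.

From the compounds shown here alone, compound 1 alone gives a number in this assay, 90100 nM, so what the exchange does to the tolerated concentration stays open on both cores. Also open, going by these compounds, is whether a longer chain such as ethylsulfanyl, or an amine, on the same carbon with a double bond to nitrogen would give a readable number rather than a limit, and so allow a step to be sized.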